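Acetamido on the sulfonyl aryl: compound 2 to compound 3

The source may hold more compounds than are shown below. What is called first, only, known or untested is meant among the compounds shown, and "the series" means these compounds.

Measured compounds:
compound 1, `CC(=O)Nc1ccc(S(=O)(=O)N2C/C(=C\c3ccccc3F)C(=O)/C(=C/c3ccccc3F)C2)cc1`: 5200 nM
compound 2, `O=C1/C(=C/c2cccc(F)c2)CN(S(=O)(=O)c2ccccc2)C/C1=C\c1cccc(F)c1`: 3400 nM

In a functional assay on HepG2 cells (Homo sapiens) for cytotoxicity, read by MTT assay, with a stated time of 24 h (on this read-out lower numbers stand for stronger inhibition and higher numbers for weaker inhibition), compound 1 gives 5200 nM and compound 2 gives 3400 nM. Compound 2 carries the lower of the two numbers, but compound 1 sits within the scatter of it, so the two cannot be told apart on these data.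

Compound 3, `CC(=O)Nc1ccc(S(=O)(=O)N2C/C(=C\c3cccc(F)c3)C(=O)/C(=C/c3cccc(F)c3)C2)cc1`, is still to be measured. It differs from compound 2 in acetamido in place of hydrogen on an aromatic carbon. Among the compounds with values here, no measured pair shows this change on its own. Compound 1 carries the same acetamido group, but its fluorine atoms stand at a different place on the attached rings, so its value cannot be read as the step itself. With the two measured numbers this close to each other, the step in this assay is expected to stay within the scatter, with no direction preferred.

For compound 3 the estimate is 4000 nM, with a range from 1500 nM to 10000 nM. The step this implies is expected to be a 1.2-fold higher number from compound 2 to compound 3 (0.07 log units; within the scatter).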

Compound 3, half-maximal inhibitory concentration: 11100 nM
For compound 3 the middle estimate is 2.8-fold (0.44 log units) below the measured one, and the stated range ends below it.
By their numbers in this assay, from the lowest: compounds 2 and 1 (each within the scatter of the next); then compound 3.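

In this assay, the change from phenyl to 4-acetamidophenyl now has a reading of its own: acetamido in place of hydrogen gives a 3.3-fold higher number from compound 2 to compound 3 (0.51 log units; beyond the scatter) as a modest step toward weaker inhibition. Compound 1 and compound 2 differ in more than one place, so they could not show this. The aromatic carbon para to a large group is now seen to respond to substitution, although this rests on a single pair with one fluorine placement on the attached rings. No measurement available here bears on the reason for the step.

Still open, going by these compounds, is whether an amine, a carboxylic acid or a longer acyl chain at this same position would give a step of similar size and direction, which would show how far the result is tied to acetamido itself. Also open is whether the step carries over to the fluorine placement of compound 1, for which no partner with an unsubstituted phenyl on the sulfonyl group is shown.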